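Single fluoro added to the diaryl urea of compound 2

The source may hold more compounds than are shown below. What is called first, only, known or untested is meant among the compounds shown, and "the series" means these compounds.

The series is tested in an assay on isolated protein for inhibition of serine/threonine-protein kinase TNNI3K (Homo sapiens); on this read-out lower numbers stand for stronger inhibition and higher numbers for weaker inhibition. Compound 1, `CNc1cc(Oc2ccc(NC(=O)Nc3cccc(C(F)(F)F)c3)c(F)c2F)ncn1`, gives 20 nM. Compound 2, `CNc1cc(Oc2ccc(NC(=O)Nc3cccc(C(F)(F)F)c3)cc2)ncn1`, gives 40 nM in this assay. Of these two numbers compound 2 carries the higher one, but the gap to compound 1 lies within the usual scatter of repeated measurements, so the two stand side by side rather than in any order. Compound 3, `CNc1cc(Oc2ccc(NC(=O)Nc3cccc(C(F)(F)F)c3)c(F)c2)ncn1`, has not yet been measured in this assay. It differs from compound 2 in one place: fluoro in place of hydrogen on an aromatic carbon. Within the data shown here, no step between two measured compounds tells the effect of this single change directly. Since compound 1 gives 20 nM with a related substitution, the account expects the step from compound 2 to compound 3 to be small, a 1.6-fold lower number from compound 2 to compound 3 (0.20 log units; within the scatter), either toward a lower number or none beyond the scatter. Compound 3 is thus estimated at 25 nM, within a range from 10 nM to 60 nM.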

Compound 3, half-maximal inhibitory concentration: 63 nM
Estimate against measurement, compound 3: 2.5-fold (0.40 log units) below, and the stated range ends below it.
By their numbers in this assay, from the lowest: compounds 1, 2 and 3 (each within the scatter of the next, the first and the last beyond it).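

In this assay, a single fluoro on this aromatic carbon, ortho to a large group, moves the read-out by no more than the scatter, with a 1.6-fold higher number from compound 2 to compound 3 (0.20 log units; within the scatter). Among these compounds, the same compound stands further from its difluoro relative, with a 3.2-fold higher number from compound 1 to compound 3 (0.50 log units; beyond the scatter), and this loss of the second fluoro of compound 1 is the only single change in this set that lies beyond the scatter, though only modestly. Thus fluoro at this position shows no effect of its own when compared with hydrogen, while the other fluoro of compound 1 does make a measurable difference in the presence of the first; no measurement shown here offers an explanation for either step.

Still open, on these data alone, is how the second fluoro would read alone on the ring of compound 2. Also open, as far as these compounds go, is whether a chlorine atom or a methoxy group on this carbon would read differently from fluoro.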